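Methoxyphenyl for bromofluorophenyl on the quinolone nitrogen

The compounds below may be only part of what the source reports. "The series", "measured", "known", "first", "only" and "open" are said of these compounds alone.

Measured compounds:
Compound 1, `COc1ccc(-n2cc(C(=O)Nc3ccc(Oc4ccnc5[nH]ccc45)cc3)c(=O)c3ccccc32)cc1`, in a functional assay on MCF7 cells (Homo sapiens) for inhibition, read by MTT assay, with a stated time of 72 h (a lower number here means a stronger inhibitor, a higher number a weaker inhibitor), gives 4650 nM.
Compound 2, `O=C(Nc1ccc(Oc2ccnc3[nH]ccc23)c(F)c1)c1cn(-c2ccc(Cl)cc2)c2ccccc2c1=O`, in this assay has "not determined" (no result reported), so no result is available for it.
Compound 3, `O=C(Nc1ccc(Oc2ccnc3[nH]ccc23)c(F)c1)c1cn(-c2ccc(Br)cc2F)c2ccccc2c1=O`, in this assay gives 1390 nM.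

Compound 3 stands at the lowest of the two numbers available. Its nearest neighbour is compound 1, whose number is higher by a gap that lies beyond the usual scatter of this assay. Compound 2 contributes no number.

The next compound, compound 4, `COc1ccc(-n2cc(C(=O)Nc3ccc(Oc4ccnc5[nH]ccc45)c(F)c3)c(=O)c3ccccc32)cc1`, is reached from compound 3 by one change: 4-methoxyphenyl in place of 4-bromo-2-fluorophenyl on an aromatic nitrogen. The group that enters is the same 4-methoxyphenyl that compound 1 carries on its aromatic nitrogen, and compound 1 sits at the weaker end of the two numbers in this assay. Among the compounds with values here, no measured pair shows this exact swap on its own, so the size of the step is uncertain. Given the value of compound 1, 4650 nM, compound 4 is expected to move toward the weaker side, with the step of a 2.5-fold higher number from compound 3 to compound 4 (0.40 log units; beyond the scatter) estimated as a moderate loss, somewhat beyond the scatter. Compound 4 is therefore estimated at 3500 nM in this assay, within a range from 1200 nM to 10000 nM.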

Compound 4, half-maximal inhibitory concentration: 6620 nM
The estimate for compound 4 lay 1.9-fold (0.28 log units) below the measured number, within the range that was stated.
By their numbers in this assay, from the lowest: compound 3; then compounds 1 and 4 (each within the scatter of the next).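

In this assay, within the data shown here, the exchange on the aromatic nitrogen gives a 4.8-fold higher number from compound 3 to compound 4 (0.68 log units; beyond the scatter), the first direct reading of this position with the rest of the molecule unchanged, and 4-bromo-2-fluorophenyl is the better of the two groups in this pair. Among these compounds, the second step, fluoro in place of hydrogen on an aromatic carbon, gives a 1.4-fold higher number from compound 1 to compound 4 (0.15 log units; within the scatter), so with 4-methoxyphenyl on the nitrogen this fluoro shows no measurable effect, and of the two changes only the one on the nitrogen moves the number beyond the scatter. Nothing measured here explains why the exchange on the nitrogen costs activity in these cells.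

The compounds shown leave open whether the bromo or the fluoro of the departing ring accounts for the step, since both leave together and compound 2, with its chlorophenyl group, has no result. They also leave open whether the fluoro on the aromatic carbon would stay as silent with 4-bromo-2-fluorophenyl on the nitrogen, and how an unsubstituted phenyl, a benzyl or a simple alkyl chain would fare at this position.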